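Adding two hydroxy groups to the terminal ring

A few compounds are considered here, and "the series" means these few. Any claim that something is new, unique, unknown or untested is made for them only; others in the source may bear on it.

Measured so far:
compound 1, `C=C/C=C\[C@H](C)[C@H](OC(N)=O)[C@@H](C)[C@H](O)[C@@H](C)C/C(C)=C\[C@H](C)[C@@H](O)[C@@H](C)/C=C\CCc1ccccc1`: 510 nM
compound 2, `C=C/C=C\[C@H](C)[C@H](OC(N)=O)[C@@H](C)[C@H](O)[C@@H](C)C/C(C)=C\[C@H](C)[C@@H](O)[C@@H](C)/C=C\CCc1cccc(O)c1`: 190 nM
compound 3, `C=C/C=C\[C@H](C)[C@H](OC(N)=O)[C@@H](C)[C@H](O)[C@@H](C)C/C(C)=C\[C@H](C)[C@@H](O)[C@@H](C)/C=C\CCc1cccc(F)c1`: 650 nM

These three compounds share one core and differ only in what sits on the aromatic ring at the end of the chain. In a functional assay on A549 cells (Homo sapiens) for cytotoxicity (a higher number here means a weaker inhibitor, a lower number a stronger inhibitor), compound 3 gives the highest of the three numbers. Its nearest neighbour is compound 1, which gives 510 nM, a gap within the usual scatter, so nothing can be said about their order. Its furthest is compound 2, which gives 190 nM; the step of a 3.4-fold higher number from compound 2 to compound 3 (0.53 log units; beyond the scatter) is beyond the scatter.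

Compound 4, `C=C/C=C\[C@H](C)[C@H](OC(N)=O)[C@@H](C)[C@H](O)[C@@H](C)C/C(C)=C\[C@H](C)[C@@H](O)[C@@H](C)/C=C\CCc1cc(O)cc(O)c1`, is not yet measured. It differs from compound 3 as follows:
3,5-dihydroxyphenyl in place of 3-fluorophenyl on a saturated chain carbon, two bonds along the chain from a double-bonded chain carbon

Among the compounds with values here, two measured steps bear on this change. The step of a 2.7-fold lower number from compound 1 to compound 2 (0.43 log units; beyond the scatter) shows that one hydroxy in place of hydrogen lowered the number modestly, and the step of a 3.4-fold higher number from compound 2 to compound 3 (0.53 log units; beyond the scatter) shows that fluoro in place of hydroxy raised it modestly, while a 1.3-fold higher number from compound 1 to compound 3 (0.11 log units; within the scatter) stayed within the scatter. The present change removes fluoro and brings in two hydroxy groups, so a modest lowering of the number is expected, with the second hydroxy untested by any measured step. Compound 4 is therefore expected to give about 220 nM in this assay, between 80 nM and 600 nM, a step of a 3.0-fold lower number from compound 3 to compound 4 (0.47 log units; beyond the scatter) from compound 3.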

Compound 4, half-maximal inhibitory concentration: 310 nM
The estimate for compound 4 lay 1.4-fold (0.15 log units) below the measured number; the measured number falls inside the stated range.
By their numbers in this assay, from the lowest: compounds 2, 4, 1 and 3 (each within the scatter of the next, the first and the last beyond it).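

In this assay, the change from 3-fluorophenyl to 3,5-dihydroxyphenyl gives a 2.1-fold lower number from compound 3 to compound 4 (0.32 log units; beyond the scatter), so this position accepts a ring carrying two hydroxy groups, and the change is a measurable one relative to the fluoro compound. The earlier compounds shown here left the second hydroxy untested, and it adds nothing that can be read: the step gives a 1.6-fold higher number from compound 2 to compound 4 (0.21 log units; within the scatter), while the comparison with the unsubstituted phenyl ring gives a 1.6-fold lower number from compound 1 to compound 4 (0.22 log units; within the scatter), so compound 4 cannot be ordered against either compound 2 or compound 1. Nothing in the data shown explains why these ring substituents give these numbers.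

On these data alone, it remains open whether a methoxy group or an amine on the ring in place of hydroxy would give numbers like those of compound 2 and compound 4. A carboxylic acid on the ring, or a longer chain between the double bond and the ring, is also an open question at this position.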